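Removing the 2-cyanoethenyl group from compound 3

The source may report more compounds than this note shows. Statements on the series, on what has been measured and on what is new or still open speak of the compounds shown alone.

Measured in a functional assay on Jurkat cells (Homo sapiens) for cytotoxicity, with a stated time of 72 h; on this read-out lower numbers stand for an effect already at smaller amounts and higher numbers for an effect only at larger amounts of compound:
compound 1 `C=C[C@@](C)(/C=C/c1ccc(O)c(/C=C/C#N)c1)CCC=C(C)C` gives > 49000 nM as a limit
compound 2 `C=C[C@@](C)(/C=C/c1ccc(O)c(/C=C/C(=O)NCc2ccc(C(F)(F)F)cc2)c1)CCC=C(C)C` gives > 49000 nM as a limit
compound 3 `COc1ccc(/C=C/[C@@](C)(/C=C/c2ccc(O)c(/C=C/C#N)c2)CCC=C(C)C)cc1` gives > 49000 nM as a limit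

Compound 3 has no exact number, only the limit > 49000 nM, and it shares the limit of > 49000 nM in this assay, at which 3 of the 3 values shown sit, with the other two compounds. Compound 4 `COc1ccc(/C=C/[C@@](C)(/C=C/c2ccc(O)cc2)CCC=C(C)C)cc1` differs from it in one place: hydrogen in place of 2-cyanoethenyl on an aromatic carbon. In words, hydrogen replaces 2-cyanoethenyl on an aromatic carbon, ortho to a hydroxy group. Among the compounds with values here, the only measured step, a step that the two limits leave unreadable from compound 1 to compound 3, changes a different group, and its size cannot be read. Within the data shown here, no step of known size or direction is therefore expected in this assay, and a result at the limit again seems likely. Expected here is a step that the limit leaves unreadable from compound 3 to compound 4, an estimate only. For compound 4 the estimated value is 60000 nM ( range 20000 nM to 150000 nM) in this expectation.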

Compound 4, half-maximal effective concentration: > 49000 nM
Compound 4 ended at the assay's limit; the forecaster's own chance of this, stated with the estimate: 80%; the middle value is on the limit's open side.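

No step can be read between compound 3 and compound 4, since each gives only a limit of the assay, as do the other compounds: the limit of > 49000 nM in this assay, at which 4 of the 4 values shown sit.

The compounds shown leave open whether hydrogen in place of 2-cyanoethenyl changes the result in this assay at all, and in which direction.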